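A New Aryl Group on an Amide-Type Nitrogen

The source may hold more compounds than are shown below. What is called first, only, known or untested is meant among the compounds shown, and "the series" means these compounds.

- compound 1 `COc1cc(Nc2ncnc3c(NC(=O)Nc4ccc(C)cc4C)cccc23)cc(OC)c1` gives 1290 nM
- compound 2 `COc1cc(Nc2ncnc3c(NC(=O)Nc4ccc(Cl)cc4)cccc23)cc(OC)c1` gives 2490 nM

Within the data shown here, in a functional assay on RT-112 cells (Homo sapiens) for antiproliferative activity, read by MTT assay, with a stated time of 72 h (on this read-out lower numbers stand for stronger inhibition of growth and higher numbers for weaker inhibition of growth), compound 2 stands level with compound 1, the only other measured compound. Compound 3 `COc1cc(Nc2ncnc3c(NC(=O)Nc4cccc(C(F)(F)F)c4F)cccc23)cc(OC)c1` is the next to consider. Its change from compound 2 is 2-fluoro-3-(trifluoromethyl)phenyl in place of 4-chlorophenyl on an amide-type nitrogen, which puts 2-fluoro-3-(trifluoromethyl)phenyl in place of 4-chlorophenyl on an amide-type nitrogen. Among the measured compounds shown here, the one measured swap at this nitrogen, a 1.9-fold higher number from compound 1 to compound 2 (0.29 log units; within the scatter), stayed within the scatter, so no step beyond the scatter is expected, though a single step is thin evidence. The estimated step is a 1.2-fold lower number from compound 2 to compound 3 (0.10 log units; within the scatter) and would stay within that scatter. For compound 3 the expected value is 2000 nM, with a likely range of 700 nM to 6000 nM.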

Compound 3, concentration for 50% growth inhibition: 471 nM
Compound 3: the middle estimate sits 4.2-fold (0.63 log units) above what was measured; the whole stated range lies above it.
By their numbers in this assay, from the lowest: compound 3; then compounds 1 and 2 (each within the scatter of the next).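

In this assay, the aryl group on this amide-type nitrogen can shift the number beyond the scatter, with 2-fluoro-3-(trifluoromethyl)phenyl in the new compound (a 5.3-fold lower number from compound 2 to compound 3 (0.72 log units; beyond the scatter)) and (a 2.7-fold lower number from compound 1 to compound 3 (0.44 log units; beyond the scatter)). Among these compounds, the earlier swap at this nitrogen stayed within the scatter, so this is the first sign that the choice of aryl group matters here. No measurement at hand accounts for the result.

Fluorine and trifluoromethyl enter together in compound 3, leaving their separate contributions open. As far as these compounds go, how an aryl group carrying an amine or a carboxylic acid would behave at this nitrogen also remains open.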